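Removing the methylsulfanyl group from a potent benzylamine

This account rests on a few compounds, and the source may have more. Where it says the series, first, only, none or still open, it means among the compounds named here.

Of the compounds shown here, three have been measured in a functional assay on MCF7 cells (Homo sapiens) for cytotoxicity, read by MTT assay, with a stated time of 72 h; a lower number here means a stronger inhibitor of growth, a higher number a weaker inhibitor of growth. Compound 1, `CSc1ccc(CNc2nc(SC)nc3ncccc23)cc1`, gives 50 nM and has the lowest number of the three. Compound 2, `COc1ccc(CNc2nc(SC)nc3ccccc23)cc1`, gives 30900 nM, and compound 3, `C[Se]c1nc(N)c2cccnc2n1`, gives 43000 nM; both of these numbers lie far above that of compound 1, well beyond the usual scatter, and neither compound differs from compound 1 in only one place.

Compound 4, `CSc1nc(NCc2ccccc2)c2cccnc2n1`, has not yet been measured. It differs from compound 1 in one place: hydrogen in place of methylsulfanyl on an aromatic carbon. Among the measured compounds shown here, no measured pair in this set shows the effect of such a change, so nothing in the data fixes the size of the step. For the measured compounds named here, the benzylamine side of compound 1 carries the methylsulfanyl group that is lost, and the only other compound with a substituted benzylamine, compound 2, is weak, though its core is different. Compound 4 is therefore expected to be somewhat weaker than compound 1, with a step of an 8.0-fold higher number from compound 1 to compound 4 (0.90 log units; beyond the scatter). The estimate for compound 4 in this assay is 400 nM, within a range from 60 nM to 4000 nM.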

Compound 4, concentration for 50% growth inhibition: 39400 nM
Compound 4: middle estimate off by 99-fold (1.99 log units), on the low side, and the stated range ends below it.
By their numbers in this assay, from the lowest: compound 1; then compounds 2, 4 and 3 (each within the scatter of the next).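

In this assay, among the compounds shown here, the one change of hydrogen in place of methylsulfanyl on an aromatic carbon gives a 790-fold higher number from compound 1 to compound 4 (2.90 log units; beyond the scatter), the first direct reading of this position, para to a large group. Nearly all of the growth inhibition seen with compound 1 is thus tied to this single methylsulfanyl group: without it, compound 4 stands with compounds 2 and 3 at the weak end of the set. Nothing available here accounts for why so small a group carries so large a step.

Whether methylsulfanyl is specifically required at this place remains open, since the compounds shown do not reveal what a chlorine atom, an amine or the longer ethylsulfanyl group would do there. Also open, going by these compounds, is whether the same change would have a step of similar size on a different core.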